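The source may hold more compounds than are shown below. What is called first, only, known or untested is meant among the compounds shown, and "the series" means these compounds.

Working notes on the series, read in a functional assay on MT4 cells (Homo sapiens) for cytotoxicity; a higher number here means that more compound is tolerated, a lower number that less compound is tolerated. Compound 1 (`CSc1nc(O)cc(C(C)c2c(F)cccc2F)n1`) gives 20800 nM. Compound 2 (`CSc1nc(O)c(C)c(C(C)c2c(F)cccc2F)n1`) gives > 200000 nM, which is a limit of the assay and not a number. Among the compounds with values here, the one measured step is an at least 9.6-fold higher number from compound 1 to compound 2 (0.98 log units; beyond the scatter), for methyl in place of hydrogen on an aromatic carbon.

Compound 3 (`Cc1c(O)nc(SC2CCCCC2)nc1C(C)c1c(F)cccc1F`) keeps that methyl and differs from compound 2 on a sulfur: cyclohexyl in place of methyl on a sulfur. In words, cyclohexyl stands in place of methyl. Within the data shown here, no measured step covers a change on the sulfur, so the size of the earlier step does not carry over directly. Compound 2 offers only a limit as a starting point, so a numerical result for compound 3 could only appear lower in this assay. Compound 1, at 20800 nM, shows that this series can give a measured number. A moderate downward move is therefore expected, though a second limit remains possible. The expected move is an at least 3.3-fold lower number from compound 2 to compound 3 (0.52 log units; beyond the scatter). For compound 3 the estimated value is 60000 nM, with an expected range of 15000 nM to 200000 nM.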

Compound 3, half-maximal cytotoxic concentration: > 200000 nM
Compound 3: a limit, no number (the forecaster's own chance of this, stated with the estimate: 35%); at least 3.3-fold (0.52 log units) between middle value and limit.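

In this assay compound 3 gives > 200000 nM as a limit of the assay and not a number. Within the data shown here, no step from compound 2 to compound 3 can be read, because both compounds sit at the same limit: the limit of > 200000 nM in this assay, at which 2 of the 3 values shown sit.

The compounds shown leave open whether cyclohexyl in place of methyl on a sulfur changes the tolerated concentration at all, and by how much.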